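Ester and sulfonate oxygen substituents on the shared core

The compounds below may be only part of what the source reports. "The series", "measured", "known", "first", "only" and "open" are said of these compounds alone.

Compound 1 `O=C(Oc1ccc(-c2cncn2C2CCN(C(=O)c3ccc(Cl)c(C(F)(F)F)c3)CC2)cc1)c1cccc2cnccc12` carries an aromatic ester on the oxygen on the aromatic ring. In an assay on HEK293 cells for antagonist activity at P2X purinoceptor 7 (Homo sapiens), read by fluorescence, with a stated time of 2 h (a lower number here means a stronger inhibitor, a higher number a weaker inhibitor), compound 1 gives > 10000 nM, which is a limit of the assay and not a number, matching (the limit of > 10000 nM in this assay, at which 1 of the 2 values shown sits). Compound 2 `CS(=O)(=O)Oc1ccc(-c2cncn2C2CCN(C(=O)c3ccc(Cl)c(C(F)(F)F)c3)CC2)cc1` replaces that ester with methylsulfonyl; in this assay compound 2 gives 1570 nM. Going by the values given here, this is the only number so far, the other value being a limit, so compound 2 is the sole point of reference. The step of an at least 6.3-fold lower number from compound 1 to compound 2 (0.80 log units; beyond the scatter) runs from a limit to a number, so its size is known only as a minimum.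

Compound 3 `CC(=O)Oc1ccc(-c2cncn2C2CCN(C(=O)c3ccc(Cl)c(C(F)(F)F)c3)CC2)cc1` is the next variation: acetyl in place of methylsulfonyl on an oxygen on an aromatic ring. Among the compounds with values here, only the step from compound 1 to compound 2 bears on this change, and it concerns a much larger group than either acetyl or methylsulfonyl; it gives little guidance on a swap between two small groups. The expectation for compound 3 is therefore a step of about a 1.4-fold higher number from compound 2 to compound 3 (0.15 log units; within the scatter) from compound 2, near the scatter, with no firm direction. Compound 3 is estimated at 2200 nM in this assay, within 600 nM to 8000 nM.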

Compound 3, half-maximal inhibitory concentration: > 10000 nM
Compound 3: no number, only a limit; the forecaster's own chance of this, stated with the estimate: 20%; at least 4.5-fold (0.65 log units) between middle value and limit.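

At this oxygen on an aromatic ring, a small group does not by itself give a readable value in this assay: acetyl in place of methylsulfonyl gives an at least 6.3-fold higher number from compound 2 to compound 3 (0.80 log units; beyond the scatter). The earlier pair changed a large aromatic ester for a small group, so it could not show that two small groups at this place can be separated in this way. Going by these compounds alone, compound 3 gives > 10000 nM, which is a limit of the assay and not a number, and the step from compound 1 to compound 3 cannot be read, leaving methylsulfonyl as the only group here with a measured number: the limit of > 10000 nM in this assay, at which 2 of the 3 values shown sit.

The compounds shown leave open whether that number is tied to the methylsulfonyl group itself or would persist with a longer chain on the sulfur, such as ethylsulfonyl, or with a phenylsulfonyl group. Also open, going by these compounds, is how a carbamate, with an amine on the carbonyl carbon in place of the methyl of acetyl, or the free hydroxyl at this oxygen would read in this assay.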